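The compounds below may be only part of what the source reports. "The series", "measured", "known", "first", "only" and "open" are said of these compounds alone.

Going by the values given here, compound 3, `Oc1cccc(-c2cc(-c3cccc(Cl)c3)nc(-c3ccco3)c2)c1`, is the only member of this small set for which a number is available in a functional assay on HCT-15 cells (Homo sapiens) for cytotoxicity, read by CCK-8 assay and cell counting, with a stated time of 2 days; on this read-out higher numbers stand for weaker inhibition and lower numbers for stronger inhibition: in that assay compound 3 gives 2460 nM. Its two companions carry no figure at all. Compound 1, `Oc1cccc(-c2cc(-c3ccncc3)nc(-c3cccc(Cl)c3)c2)c1`, is recorded in this assay as "not determined" (no result reported), and compound 2, `Oc1cccc(-c2cc(-c3cccc(Cl)c3)nc(-c3ccccn3)c2)c1`, likewise as "not determined" (no result reported). Compound 3 therefore stands alone on the numbers shown, with no second value beside it to say whether it is strong or weak within its own series, and no step between measured compounds can be drawn from these three.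

Compound 4, `Oc1cccc(-c2cc(-c3ccc(Cl)cc3)nc(-c3ccco3)c2)c1`, is the compound still to be measured. It differs from compound 3 in a single place: 4-chlorophenyl in place of 3-chlorophenyl on an aromatic carbon. The two share every atom and are simply joined differently.

Among the compounds with values here, with no measured pair to show what such a rearrangement does in this assay, there is nothing in the data to point one way or the other. The step expected from compound 3 to compound 4 is therefore a 1.0-fold higher number from compound 3 to compound 4 (0.01 log units; within the scatter), a change estimated to fall within the ordinary scatter rather than beyond it. On that basis compound 4 is expected to give about 2500 nM in this assay, within a range from 900 nM to 7000 nM.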

Compound 4, half-maximal inhibitory concentration: 10200 nM
The estimate for compound 4 lay 4.1-fold (0.61 log units) below the measured number; measured number outside the range, above it.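

In this assay, 4-chlorophenyl in place of 3-chlorophenyl on the aromatic carbon next to the ring nitrogen gives a 4.1-fold higher number from compound 3 to compound 4 (0.62 log units; beyond the scatter), which means weaker inhibition for compound 4. Going by these compounds alone, this is the first step that can be read in the set, and it shows that this position is sensitive to where the chlorine sits on the phenyl ring, even though the group entering and the group leaving have the same atoms and the same counts. Nothing at hand explains why this rearrangement weakens the read-out, so the result stands here as an observation without a cause.

Steps involving compound 1 or compound 2 cannot be read, since neither has a reported number, so it remains unknown whether this difference between the two chlorophenyl groups would persist with anything other than furan-2-yl on the shared core. Also open, on these data alone, is how a 2-chlorophenyl group, a plain phenyl group or a 3-aminophenyl group would compare at this place, so the two chlorophenyl groups do not yet define a trend for the position.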